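Furan for Benzofuran on Two Nucleoside Cores

The source may report more compounds than this note shows. Statements on the series, on what has been measured and on what is new or still open speak of the compounds shown alone.

Compound 2 `O=c1[nH]cnc2c1c(-c1cc3ccccc3o1)cn2[C@@H]1O[C@H](CO)[C@@H](O)[C@H]1O` carries a 1-benzofuran-2-yl group on its core, and compound 1 `O=c1[nH]cnc2c1c(-c1ccco1)cn2[C@@H]1O[C@H](CO)[C@@H](O)[C@H]1O` carries a furan-2-yl group in the same place. In a functional assay on CEM-DNR-bulk cells (Homo sapiens), read by MTT assay, with a stated time of 72 h (a higher number here means a weaker inhibitor, a lower number a stronger inhibitor), compound 2 reaches only the limit of the measurement, > 20000 nM. Compound 1 likewise reaches only that limit, > 20000 nM. The step that the two limits leave unreadable from compound 2 to compound 1 therefore cannot be sized, as both values sit at the limit (the limit of > 20000 nM in this assay, at which 3 of the 3 values shown sit). The change itself is furan-2-yl in place of 1-benzofuran-2-yl on an aromatic carbon.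

Compound 3 `Nc1nc(N)c2c(-c3cc4ccccc4o3)cn([C@@H]3O[C@H](CO)[C@@H](O)[C@H]3O)c2n1` rests on a different core; how the two cores differ is not broken down here. In this assay compound 3 also returns only a limit, > 20000 nM. Compound 4 `Nc1nc(N)c2c(-c3ccco3)cn([C@@H]3O[C@H](CO)[C@@H](O)[C@H]3O)c2n1` has not been measured and is related to compound 3 by the same change, (furan-2-yl in place of 1-benzofuran-2-yl on an aromatic carbon); the surroundings of the place read alike for both changes.

Among the compounds with values here, because every measured value so far sits at the limit (the limit of > 20000 nM in this assay, at which 3 of the 3 values shown sit), the step that is expected a step that the limit leaves unreadable from compound 3 to compound 4 rests on nothing firmer than that limit. Compound 4 is therefore expected to return a value close to the limit again, estimated as 25000 nM.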

Compound 4, half-maximal inhibitory concentration: > 20000 nM
Compound 4: a limit, no number (the forecaster's own chance of this, stated with the estimate: 85%); the middle value lies beyond the limit too.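

In this assay compound 4 returns only a limit, > 20000 nM. The step from compound 3 to compound 4 therefore cannot be read, as both compounds stand at a limit: the limit of > 20000 nM in this assay, at which 4 of the 4 values shown sit. The compounds shown leave open whether exchanging 1-benzofuran-2-yl for furan-2-yl changes the potency on either core.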